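Swapping a cyano-substituted phenyl for a cyclohexyl ring

The source may hold more compounds than are shown below. What is called first, only, known or untested is meant among the compounds shown, and "the series" means these compounds.

Compound 1, `CC[C@H](C)[C@H](N)CN(C(=O)[C@@H]1C[C@H]1c1ccccc1F)c1ccc(-c2ccccc2)cc1`, gives 650 nM in a functional assay for agonist activity at G protein-coupled receptor 88 (Homo sapiens), read by HTRF and cAMP accumulation; on this read-out lower numbers stand for an effect already at smaller amounts and higher numbers for an effect only at larger amounts of compound.
Compound 2, `CC[C@H](C)[C@H](N)CN(C(=O)[C@@H]1C[C@H]1c1cccc(C)c1)c1ccc(-c2ccccc2)cc1`, gives 1200 nM.
Compound 3, `CC[C@H](C)[C@H](N)CN(C(=O)[C@@H]1C[C@H]1c1cccc(C#N)c1)c1ccc(-c2ccccc2)cc1`, gives 1600 nM.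

Compound 3 holds the highest of the three numbers in this assay. Its closest neighbour is compound 2: the step of a 1.3-fold higher number from compound 2 to compound 3 (0.12 log units; within the scatter), so the two cannot be told apart. Against compound 1 the gap is larger: a 2.5-fold higher number from compound 1 to compound 3 (0.39 log units; beyond the scatter), a modest weakening.

Compound 4, `CC[C@H](C)[C@H](N)CN(C(=O)[C@@H]1C[C@H]1C1CCCCC1)c1ccc(-c2ccccc2)cc1`, differs from compound 3 in one place: cyclohexyl in place of 3-cyanophenyl on a saturated ring carbon. All three measured steps change the same ring at the same saturated ring carbon, but each keeps an aromatic ring there. The step of a 1.8-fold higher number from compound 1 to compound 2 (0.27 log units; within the scatter) lies within the scatter, and the step of a 2.5-fold higher number from compound 1 to compound 3 (0.39 log units; beyond the scatter) is only modest. Among the compounds with values here, no measured step replaces an aromatic ring with a saturated one, so the data speak to this change only indirectly, and they show that altering this ring has moved the number little. On that basis a small step is expected, a 1.4-fold higher number from compound 3 to compound 4 (0.14 log units; within the scatter), with the direction uncertain and a slight lean toward a higher number. Compound 4 is therefore estimated at 2200 nM, within a range from 700 nM to 7000 nM.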

Compound 4, half-maximal effective concentration: > 25000 nM
Compound 4 gave a limit, no number (the forecaster's own chance of this, stated with the estimate: 15%); middle value at least 11-fold (1.05 log units) away from the limit.
By their numbers in this assay, from the lowest: compounds 1, 2 and 3 (each within the scatter of the next, the first and the last beyond it). At a limit, above all of these: compound 4.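

In this assay, compound 4 gives > 25000 nM, which is a limit of the assay and not a number, and it is the only such value here: the limit of > 25000 nM in this assay, at which 1 of the 4 values shown sits.

Even so, the gap can be read against each aromatic compound, and all three steps are large: an at least 15-fold higher number from compound 3 to compound 4 (1.19 log units; beyond the scatter), an at least 20-fold higher number from compound 2 to compound 4 (1.31 log units; beyond the scatter) and an at least 38-fold higher number from compound 1 to compound 4 (1.58 log units; beyond the scatter). The earlier compounds kept an aromatic ring on this saturated ring carbon of the three-membered ring, and changing the substituents on that ring moved the number only a little, whereas going to a non-aromatic six-membered ring moves it far more, so among these four compounds the divide at this position lies between an aromatic and a non-aromatic ring, and it does not depend on the nitrile, since compound 1 and compound 2 have none and show the same large step.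

From the compounds shown here alone, what stays open is whether any saturated group can work at this carbon, for example a smaller cyclopentyl or cyclopropyl ring. Going by these compounds, it is equally open how an aromatic ring holding nitrogen, such as a pyridyl ring, or an open chain such as n-butyl would behave there.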